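A few compounds are considered here, and "the series" means these few. Any claim that something is new, unique, unknown or untested is made for them only; others in the source may bear on it.

Measured compounds in a functional assay on SNB-75 cells (Homo sapiens) for inhibition, read by sulforhodamine B assay, with a stated time of 48 h, tested at 10 uM; a higher number here means more inhibition at the concentration tested (going by the name of the read-out), a lower number less inhibition:
- compound 1 `Brc1cn2ccnc2c(-c2ccc3ncn(C4CCCCC4)c3c2)n1` gives 21.3%
- compound 2 `c1ccc2c(-c3cn4ccnc4c(-c4ccc5ncn(C6CCCCC6)c5c4)n3)cccc2c1` gives 16.5%
- compound 3 `Brc1ccc(-c2cn3ccnc3c(-c3ccc4ncn(C5CCCCC5)c4c3)n2)cc1` gives 34.6%

Compound 3 holds the highest of the three numbers. Its lead over compound 1 is a number 13.3 percentage points higher from compound 1 to compound 3 (beyond the scatter), and over compound 2 it is a number 18.1 percentage points higher from compound 2 to compound 3 (beyond the scatter), both beyond the scatter. Between compound 1 and compound 2 the step is a number 4.8 percentage points lower from compound 1 to compound 2 (within the scatter), which lies within the scatter.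

Compound 4 `Fc1ccccc1-c1cn2ccnc2c(-c2ccc3ncn(C4CCCCC4)c3c2)n1` has not yet been measured. It differs from compound 3 in one place: 2-fluorophenyl in place of 4-bromophenyl on an aromatic carbon. Both steps that end at compound 3 show a change of the group on this aromatic carbon moving the number by a modest amount; the bromo of compound 1 and the naphthalen-1-yl of compound 2 both sit lower than the 4-bromophenyl of compound 3. A new six-membered carbon ring with a different halogen may therefore shift this assay modestly in either direction, most likely somewhat downward. Compound 4 is expected to give 27%, estimated between 12% and 42%, an expected step of a number 7.6 percentage points lower from compound 3 to compound 4 (within the scatter).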

Compound 4, a percentage reported as inhibition, at one concentration (the size of the read-out at that concentration, not a potency): 29.7%
Estimate against measurement, compound 4: 2.7 percentage points below; the range from low to high includes it.
By their numbers in this assay, from the lowest: compounds 2, 1, 4 and 3 (each within the scatter of the next, the first and the last beyond it).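

In this assay, replacing 4-bromophenyl with 2-fluorophenyl on this aromatic carbon gives a number 4.9 percentage points lower from compound 3 to compound 4 (within the scatter) and so does not move the number beyond the scatter, although both the halogen and its place on the phenyl ring differ. In place of naphthalen-1-yl, the 2-fluorophenyl gives a number 13.2 percentage points higher from compound 2 to compound 4 (beyond the scatter) as the 4-bromophenyl also did, but in place of bromo it gives a number 8.4 percentage points higher from compound 1 to compound 4 (within the scatter) and so lacks the clear separation from bromo that the 4-bromophenyl showed. Nothing available explains why these steps take the sizes they do.

Since the halogen and its place changed together, the compounds shown cannot separate the two. Going by these compounds, it also remains open how an amine or a carboxylic acid on this carbon would read in this assay at the same concentration.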